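The source may report more compounds than this note shows. Statements on the series, on what has been measured and on what is new or still open speak of the compounds shown alone.

Measured in a functional assay, read by fluorescence and spectrophotometry, with a stated time of 1 h; a higher number here means that more compound is needed for the effect, a lower number that less compound is needed:
compound 1 `CCCCCCCCCCCCS(=O)(=O)/C=C/c1ccc(O)c(O)c1` gives 8500 nM;
compound 2 `O=S(=O)(/C=C/c1ccc(O)c(O)c1)CC1CCCN1` gives 13800 nM;
compound 3 `CCCCCCS(=O)(=O)/C=C/c1ccc(O)c(O)c1` gives 7300 nM.

Compound 3 shows the lowest of the three numbers, yet both gaps to it lie within the scatter: a 1.2-fold lower number from compound 1 to compound 3 (0.07 log units; within the scatter) and a 1.9-fold lower number from compound 2 to compound 3 (0.28 log units; within the scatter). No order among the three compounds is therefore established in this assay.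

Compound 4 `C=CCCCCCCCS(=O)(=O)/C=C/c1ccc(O)c(O)c1` is not yet measured. Its change from compound 3: allyl in place of hydrogen on a saturated chain carbon, six bonds along the chain from a sulfonyl sulfur. The step that bears on it is a 1.2-fold lower number from compound 1 to compound 3 (0.07 log units; within the scatter), the same chain position, where hexyl or hydrogen read almost alike and within the scatter. Allyl entering there is thus expected to move this assay by no step beyond the scatter, in no particular direction. Compound 4 is expected to give 7500 nM, within 4000 nM to 14000 nM, an expected step of a 1.0-fold higher number from compound 3 to compound 4 (0.01 log units; within the scatter).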

Compound 4, half-maximal effective concentration: 6900 nM
For compound 4 the middle estimate is 1.1-fold (0.04 log units) above the measured one; low and high end bracket the measured number.
By their numbers in this assay, from the lowest: compounds 4, 3, 1 and 2 (each within the scatter of the next).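

In this assay, allyl brings a double bond outside aromatic rings to this saturated chain position, and the step stays within the scatter (a 1.1-fold lower number from compound 3 to compound 4 (0.02 log units; within the scatter)). Vinyl in place of pentyl, seven bonds along the chain from a sulfonyl sulfur, also stays within the scatter (a 1.2-fold lower number from compound 1 to compound 4 (0.09 log units; within the scatter)). Unsaturation in this part of the chain therefore separates neither compound 4 from compound 3 nor compound 4 from compound 1, and no measured evidence offers an explanation for these readings.

Going by these compounds, whether a carboxylic acid or an amine at this chain position would give a step beyond the scatter remains open.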